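The compounds below may be only part of what the source reports. "The series", "measured", "known", "first", "only" and "open" are said of these compounds alone.

Measured compounds: compound 1 `Cc1ccc(-n2cc(CNC(=O)c3cccc4c3cnn4C(C)C)nn2)c(C)c1` gives > 40000 nM in a functional assay on MCF7 cells (Homo sapiens) for inhibition, read by MTT assay, with a stated time of 72 h; a lower number here means a stronger inhibitor, a higher number a weaker inhibitor. Compound 2 `CC(C)n1ncc2c(C(=O)NCc3cn(-c4ccc([N+](=O)[O-])cc4)nn3)cccc21` gives > 40000 nM in this assay.

Compound 1 thus stands at a limit of the assay rather than at a measured number. Compound 2 sits at a limit as well. Going by the values given here, the only measured step, a step that the two limits leave unreadable from compound 1 to compound 2, is unreadable for that reason, and the sole evidence available is the limit of > 40000 nM in this assay, at which 2 of the 2 values shown sit. Compound 3 `Cc1ccc(-n2cc(CNC(=O)c3cccc4c3cnn4C(C)C)nn2)cc1` differs from compound 1 by hydrogen in place of methyl on an aromatic carbon. Among the compounds with values here, no measured step touches this change, so no step beyond the scatter, in either direction, is expected in this assay. Compound 3 is therefore estimated at 50000 nM, between 15000 nM and 200000 nM. The expected step that the limit leaves unreadable from compound 1 to compound 3 leaves compound 3 most likely at the limit.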

Compound 3, half-maximal inhibitory concentration: > 40000 nM
Compound 3 ended at the assay's limit; the forecaster's own chance of this, stated with the estimate: 85%; the middle value lies beyond the limit too.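

Going by these compounds alone, compound 3 also sits at a limit in this assay, so no step among compound 1, compound 2 and compound 3 can be read: the limit of > 40000 nM in this assay, at which 3 of the 3 values shown sit. The compounds shown leave open how far each lies beyond that limit, and whether any of these changes affects inhibition.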